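Aryl on the aromatic nitrogen: what to expect for compound 4

This account rests on a few compounds, and the source may have more. Where it says the series, first, only, none or still open, it means among the compounds named here.

Compound 1 `CCn1ccnc1-c1cc(OC)c(OC)c(OC)c1` carries an ethyl group on the aromatic nitrogen of the shared core. In a functional assay on MDA-MB-468 cells (Homo sapiens) for antiproliferative activity, read by MTT assay, with a stated time of 72 h (a higher number here means a weaker inhibitor, a lower number a stronger inhibitor), compound 1 gives only a limit, > 100000 nM. Compound 2 `COc1cc(-c2nccn2Cc2ccccc2)cc(OC)c1OC` carries a phenyl in place of methyl on a saturated chain carbon bound to the aromatic nitrogen. In this assay compound 2 also gives only a limit, > 100000 nM. The step that the two limits leave unreadable from compound 1 to compound 2 is thus not readable. Compound 3 `COc1cc(-c2nccn2-c2ccc(C)cc2)cc(OC)c1OC` bears a 4-methylphenyl on the aromatic nitrogen, and in this assay compound 3 gives 400 nM. The two steps toward it, an at least 250-fold lower number from compound 1 to compound 3 (2.39 log units; beyond the scatter) and an at least 250-fold lower number from compound 2 to compound 3 (2.39 log units; beyond the scatter), are both large; that two of the three values sit at the limit of > 100000 nM in this assay, at which 2 of the 3 values shown sit, leaves their full size open. Compound 1 therefore stands at the weak end of what has been measured, with no number of its own.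

Compound 4 `COc1ccc(-n2ccnc2-c2cc(OC)c(OC)c(OC)c2)cc1` awaits measurement in this assay. Its change from compound 1 is 4-methoxyphenyl in place of ethyl on an aromatic nitrogen. The step that bears on it is an at least 250-fold lower number from compound 1 to compound 3 (2.39 log units; beyond the scatter), where an aromatic ring likewise enters on the aromatic nitrogen. For compound 4 a step of the same direction and comparable size is expected: an at least 250-fold lower number from compound 1 to compound 4 (2.39 log units; beyond the scatter). Compound 4 is estimated at 400 nM, within a range from 100 nM to 2000 nM.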

Compound 4, half-maximal inhibitory concentration: 500 nM
Beside the measured number, compound 4's estimate is 1.3-fold (0.10 log units) below it, within the range that was stated.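

Compound 4 shows that the large gain with an aromatic ring on the aromatic nitrogen does not rest on compound 3 alone: in this assay the 4-methoxyphenyl group gives an at least 200-fold lower number from compound 1 to compound 4 (2.30 log units; beyond the scatter), and in place of benzyl it gives an at least 200-fold lower number from compound 2 to compound 4 (2.30 log units; beyond the scatter). The substituent on that ring can also differ without a readable effect, since methoxy in place of methyl on an aromatic carbon gives a 1.3-fold higher number from compound 3 to compound 4 (0.10 log units; within the scatter), so compound 3 and compound 4 cannot be separated in this assay. The full size of the two large steps stays open because the weaker partner in each gives only a limit: the limit of > 100000 nM in this assay, at which 2 of the 4 values shown sit.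

The compounds shown place only 4-methylphenyl and 4-methoxyphenyl on the aromatic nitrogen, so it remains open whether an unsubstituted phenyl, a 4-aminophenyl or a 4-carboxyphenyl group would read like them. On these data alone, it also remains open whether a longer chain, such as n-hexyl, on the same nitrogen would stay with ethyl and benzyl at the weak end of the series.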